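A few compounds are considered here, and "the series" means these few. Any claim that something is new, unique, unknown or untested is made for them only; others in the source may bear on it.

Three compounds share a core built from a bicyclic aromatic unit carrying a triazole, joined through a three-carbon chain to a saturated nitrogen ring, and differ only in the group on that ring. Compound 1 `c1ccc(C2CCCCN2C2CCN(CCCc3c[nH]c4ccc(-n5cnnc5)cc34)CC2)cc1` carries a phenyl-bearing saturated ring there, and in an assay on CHO cells for displacement of a labelled ligand from 5-hydroxytryptamine receptor 1D (Homo sapiens) (on this read-out higher numbers stand for weaker inhibition and lower numbers for stronger inhibition), compound 1 gives 1.9 nM. Compound 2 `CC(C)=CCCN(C)C1CCN(CCCc2c[nH]c3ccc(-n4cnnc4)cc23)CC1` carries a methyl(4-methylpent-3-en-1-yl)amino group, and in this assay compound 2 gives 2.6 nM. Compound 3 `CC(=O)Nc1ccc([C@H](C)NCC2CCN(CCCc3c[nH]c4ccc(-n5cnnc5)cc34)CC2)cc1` carries an amine linked to an acetamido-substituted aromatic ring, and in this assay compound 3 gives 0.6 nM.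

Compound 2 has the highest of the three numbers. Its gap to compound 1 lies within the usual scatter, so the two cannot be told apart; its gap to compound 3 lies beyond the scatter, so compound 3 clearly binds more strongly.

Compound 4 `c1ccc(CNC2CCN(CCCc3c[nH]c4ccc(-n5cnnc5)cc34)CC2)cc1` has not yet been measured. The change is benzylamino in place of methyl(4-methylpent-3-en-1-yl)amino on a saturated ring carbon. Within the data shown here, no measured pair isolates this change, so the expectation rests on the spread of the three measured compounds. The step from compound 2 to compound 4 is expected to be small and toward a lower number, a 1.7-fold lower number from compound 2 to compound 4 (0.24 log units; within the scatter), because compound 3, which also pairs a hydrogen-bond-donating amine with an aromatic ring, gives 0.6 nM. For compound 4 in this assay the estimate is 1.5 nM, with a range from 0.5 nM to 5 nM.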

Compound 4, half-maximal inhibitory concentration: 4.6 nM
For compound 4 the middle estimate is 3.1-fold (0.49 log units) below the measured one; low and high end bracket the measured number.
By their numbers in this assay, from the lowest: compound 3; then compounds 1, 2 and 4 (each within the scatter of the next, the first and the last beyond it).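

Among these compounds, the step from compound 2 to compound 4 is the first comparison in this set in which only one group changes, so it is the first direct look at this position, a saturated ring carbon three ring bonds from the ring nitrogen. Methyl(4-methylpent-3-en-1-yl)amino, with no ring, 1 double bond and 0 hydrogen-bond donors, gives way to benzylamino, with one six-membered aromatic ring of carbon only and 1 hydrogen-bond donor, while the count of 8 heavy atoms stays the same, and in this assay this yields a 1.8-fold higher number from compound 2 to compound 4 (0.25 log units; within the scatter), so the two groups cannot be told apart on this read-out and binding at the receptor survives a marked change in the group's make-up. Nothing in the data shown explains this outcome.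

The compounds shown leave open whether a small group such as a primary amine or a hydroxyl on this ring carbon would keep binding in the same range, since both groups compared here are of the same size. On these data alone, it is also open how a carboxylic acid, or a phenethylamino group with its longer chain, would fare in this place.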